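Aryl sulfonyl series: the step to compound 3

The compounds below may be only part of what the source reports. "The series", "measured", "known", "first", "only" and "open" are said of these compounds alone.

Values so far in a functional assay on HeLa cells (Homo sapiens) for antiproliferative activity, read by MTT assay, with a stated time of 72 h (a lower number here means a stronger inhibitor, a higher number a weaker inhibitor), by compound
- compound 1 (`N=C(NS(=O)(=O)c1ccccc1)N1CCN(c2cc3c(cc2F)c(=O)c(C(=O)O)cn3C2CC2)CC1`): 32 nM
- compound 2 (`N=C(NS(=O)(=O)c1cccc(Cl)c1)N1CCN(c2cc3c(cc2F)c(=O)c(C(=O)O)cn3C2CC2)CC1`): 32 nM

Level with compound 1, compound 2 stands at 32 nM on the numbers so far. Compound 3 (`N=C(NS(=O)(=O)c1ccc(C(F)(F)F)cc1)N1CCN(c2cc3c(cc2F)c(=O)c(C(=O)O)cn3C2CC2)CC1`) carries 4-(trifluoromethyl)phenyl in place of 3-chlorophenyl on a sulfonyl sulfur. Among the compounds with values here, one measured step bears on this change: chloro in place of hydrogen on an aromatic carbon, which gave no change at the digits printed from compound 1 to compound 2 (within the scatter) and stays within the scatter. Within the data shown here, it is a single step, and no measured compound carries trifluoromethyl, so the data offer no direction. No step beyond the scatter is expected in this assay and no direction is favoured, which leaves an expected no change at the digits printed from compound 2 to compound 3 (within the scatter) as the working figure. Expected for compound 3 is 32 nM within 12 nM to 85 nM as the estimated range.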

Compound 3, half-maximal inhibitory concentration: 32 nM
Compound 3: the middle estimate sits on the measured number at the digits printed; the range from low to high includes it.
By their numbers in this assay, from the lowest: compounds 1, 2 and 3 (each within the scatter of the next).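

In this assay the step from a 3-chlorophenyl to a 4-(trifluoromethyl)phenyl on the sulfonyl sulfur gives no change at the digits printed from compound 2 to compound 3 (within the scatter) and the trifluoromethyl added to the otherwise bare phenyl gives no change at the digits printed from compound 1 to compound 3 (within the scatter) in the same assay. The flat reading of the chloro step is therefore not confined to that one substituent: phenyl in compound 1, 3-chlorophenyl in compound 2 and the larger 4-(trifluoromethyl)phenyl in compound 3 all read alike at this position. No measurement at hand offers an explanation for this flat reading.

On these data alone, whether the level holds with an amine or a carboxylic acid on the aromatic ring remains open. Also open, as far as these compounds go, is the effect of a methyl or a longer alkyl chain in place of the aryl group on the sulfonyl sulfur.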